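This account rests on a few compounds, and the source may have more. Where it says the series, first, only, none or still open, it means among the compounds named here.

Measured compounds:
compound 1 `Nc1ncc(-c2ccccc2)c(-c2ccccc2)n1`: 32%
compound 2 `COc1ccccc1-c1cnc(N)nc1-c1ccccc1`: 20%
compound 3 `COc1ccc(-c2cnc(N)nc2-c2ccccc2)cc1OC`: > 80%

In an assay on CHO cells for displacement of a labelled ligand from adenosine receptor A1 (Homo sapiens), read by scintillation counting, with a stated time of 1 h, tested at 1 uM (a higher number here means more inhibition at the concentration tested (going by the name of the read-out), a lower number less inhibition), compound 1 gives 32% and compound 2 gives 20%. The step between them, a number 12 percentage points lower from compound 1 to compound 2 (beyond the scatter), comes with a change of methoxy in place of hydrogen on an aromatic carbon. For compound 3 the value > 80% is a limit of the assay, not a number; it sits at the limit of > 80% in this assay, at which 1 of the 3 values shown sits. The difference between the core of compound 1 and the core of compound 3 is not broken down here.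

Compound 4 `COc1cc(-c2cnc(N)nc2-c2ccccc2)cc(OC)c1OC` is not yet measured. It differs from compound 3 by methoxy in place of hydrogen on an aromatic carbon. This is the same kind of change as from compound 1 to compound 2, but not the same: there the new group stood ortho to a large group, here it stands ortho to a methoxy group, meta to a large group and meta to a methoxy group. With compound 3 at a limit, a comparable modest step of a number at least 2 percentage points lower from compound 3 to compound 4 (that floor lies within the scatter) is expected, though the limit leaves its size uncertain. Compound 4 is estimated at 78%, between 55% and 95%.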

Compound 4, a percentage reported as inhibition, at one concentration (the size of the read-out at that concentration, not a potency): 56%
Compound 4: middle estimate off by 22 percentage points, on the high side, within the range that was stated.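

In this assay, methoxy in place of hydrogen on an aromatic carbon again goes with a lower number, a number at least 24 percentage points lower from compound 3 to compound 4 (beyond the scatter), so the direction is shared by the two pairs: the same change on two cores in this assay, a number 12 percentage points lower (beyond the scatter) from compound 1 to compound 2 and a number at least 24 percentage points lower (beyond the scatter) from compound 3 to compound 4; the limit leaves it open whether they differ

The value of compound 3, > 80%, is a limit of the assay and not a number: the limit of > 80% in this assay, at which 1 of the 4 values shown sits.

The shared direction therefore says nothing about whether the size of the step carries from one core to the other, and the new methoxy does not stand in the same place in the two pairs, so two pairs set no general rule for the series.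

The compounds shown leave open whether a hydroxyl, an amine or a longer chain such as ethoxy in the same place would go the same way as methoxy. Also open, from the compounds shown here alone, is whether the same change on the other six-membered aromatic ring of carbon only would give a step in the same direction.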